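A few compounds are considered here, and "the series" means these few. Any claim that something is new, unique, unknown or untested is made for them only; others in the source may bear on it.

Three compounds make up the measured set. Among the compounds with values here, compound 1 `Cc1nn([C@H](C)c2ccc(Cl)cc2Cl)c2nc(N3CC[C@H](N4CCC[C@H]4CCS(C)(=O)=O)[C@H](C)C3)cnc12` carries a 2-(methylsulfonyl)ethyl group on its pyrrolidine; compound 2 `Cc1nn([C@H](C)c2ccc(Cl)cc2Cl)c2nc(C3=CC[C@H](N4CCC[C@H]4CO)[C@H](C)C3)cnc12` and compound 3 `C[C@@H]1CC(c2cnc3c(C#N)nn([C@H](C)c4ccc(Cl)cc4Cl)c3n2)=CC[C@@H]1N1CCC[C@H]1C(C)(C)O` differ from it in several places at once, so no single step connects any pair. In a functional assay on cells for antagonist activity at C-C chemokine receptor type 4 (Homo sapiens), read by fluorescence and calcium flux, with stated times of 2.5 s and 45 s (on this read-out higher numbers stand for weaker inhibition and lower numbers for stronger inhibition), compound 1 gives 104 nM. In this assay compound 2 gives 36 nM, and compound 3 gives 384 nM. Compound 1 therefore stands second highest of the three: its number lies above that of compound 2 and below that of compound 3, and both gaps are beyond the scatter of repeated measurements.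

Compound 4 `Cc1nn([C@H](C)c2ccc(Cl)cc2Cl)c2nc(N3CC[C@H](N4CCC[C@H]4CCC(N)=O)[C@H](C)C3)cnc12` is not yet measured. It departs from compound 1 in one place: carbamoyl in place of methylsulfonyl on a saturated chain carbon, two bonds along the chain from a saturated ring carbon. The rest of the molecule, including the shared core and the substituted pyrrolidine, is unchanged.

Within the data shown here, no measured pair shows this particular exchange, so the expectation rests on compound 1 alone. Since the group that leaves and the group that enters are both small and uncharged, the step from compound 1 to compound 4 is expected to be a 1.2-fold higher number from compound 1 to compound 4 (0.06 log units; within the scatter), not beyond the scatter in either direction. On that basis compound 4 is estimated at 120 nM in this assay, with a range from 50 nM to 300 nM.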

Compound 4, half-maximal inhibitory concentration: 37 nM
For compound 4 the middle estimate is 3.2-fold (0.51 log units) above the measured one, and the stated range ends above it.
By their numbers in this assay, from the lowest: compounds 2 and 4 (each within the scatter of the next); then compound 1; then compound 3.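

In this assay, carbamoyl in place of methylsulfonyl on a saturated chain carbon, two bonds along the chain from a saturated ring carbon, gives a 2.8-fold lower number from compound 1 to compound 4 (0.45 log units; beyond the scatter). The earlier compounds shown here could not show this, since no single step connected any pair of them; this step shows that the number at this position responds to the group at the end of the chain, modestly but beyond the scatter, and that inhibition is stronger with 2-carbamoylethyl than with 2-(methylsulfonyl)ethyl. The carbamoyl group differs from methylsulfonyl in its heavy atoms, double bonds and hydrogen-bond donors and acceptors, but no measurement here ties the step to any of these differences or otherwise accounts for it.

The compounds shown leave open whether other end groups on this chain, such as a carboxylic acid, an amine or an N,N-dimethylcarbamoyl group, would give a similar number, and whether a longer chain would keep the step. They also leave open whether the same exchange would give a step of similar size on a different core.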